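The compounds below may be only part of what the source reports. "The series", "measured", "known", "first", "only" and "open" are said of these compounds alone.

Of the compounds shown here, two built on one shared core have been measured in an assay on isolated protein (Mus musculus) for inhibition of IL15-IL15 receptor (Homo sapiens), read by resazurin assay, with stated times of 30 min and 2.5 days; on this read-out lower numbers stand for stronger inhibition and higher numbers for weaker inhibition. Compound 1 `Cn1c(Cc2nn(C)c(=O)c3ccccc23)nnc1SCCCCCCCCCCC(=O)Oc1ccc(Cl)cc1Cl` gives 8700 nM in this assay. Compound 2 `CC(C)COc1ccc(NC(=O)CSc2nnc(Cc3nn(C)c(=O)c4ccccc34)n2C)cc1` gives 30000 nM, which is the higher of the two numbers; the number for compound 1 sits lower by a margin beyond the usual scatter, so compound 1 is the more potent of the pair. Compound 3 `Cn1c(Cc2nn(C)c(=O)c3ccccc23)nnc1SCC(=O)Nc1ccc(I)cc1` has not been measured yet. It differs from compound 2 in one place: iodo in place of isobutoxy on an aromatic carbon. Among the measured compounds shown here, no two measured compounds differ from each other in just a single group, so there is no measured step to show what this kind of exchange does on this core. Both measured numbers are high, meaning only weak inhibition has been seen so far. Compound 3 is expected to stay in that weak range. The step is expected to be small, a 1.5-fold lower number from compound 2 to compound 3 (0.18 log units; within the scatter), and may well lie within the scatter. The estimate for compound 3 is 20000 nM, within a range from 6000 nM to 70000 nM, because compound 2 gives 30000 nM and compound 1 gives 8700 nM.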

Compound 3, half-maximal inhibitory concentration: "not active" (no number reported)
Compound 3 has no reported number here; no gap can be computed for the estimate.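

In this assay, among the compounds shown here, compound 3 is reported as "not active" with no number, so no step from compound 2 to compound 3 can be read. No available data offer an explanation for this result. The compounds shown leave open how much inhibition changes when 4-iodophenyl replaces 4-(isobutoxy)phenyl on the shared core.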